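Three Inactive Compounds and an Untested Ester

The compounds below may be only part of what the source reports. "The series", "measured", "known", "first", "only" and "open" are said of these compounds alone.

In an ADME assay on cells (Fibroblast, Homo sapiens) for antiproliferative activity, with a stated time of 48 h (a lower number here means a stronger inhibitor, a higher number a weaker inhibitor), compound 1 `COC(=O)c1cccc(-c2ccc(-n3cccc3)nn2)c1` gives > 25000 nM, which is a limit and not a number. Compound 2 `CCN(CC)c1ccc(-c2cccc(C#N)c2)nn1` gives > 25000 nM, again only a limit. Compound 3 `CCN(CC)c1ccc(-c2ccc(C#N)cc2)nn1` gives > 25000 nM, likewise a limit. Compound 3 therefore has no numerical potency to compare, and it stands with the other two compounds: the limit of > 25000 nM in this assay, at which 3 of the 3 values shown sit. Within the data shown here, no measured pair in this small set differs in only one place, so the data show no measured step to use as a guide.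

Compound 4 `CCOC(=O)c1ccc(-c2ccc(N(CC)CC)nn2)cc1` keeps the diethylamino side of compound 3 and carries ethoxycarbonyl in place of cyano on an aromatic carbon, para to a large group: ethoxycarbonyl in place of cyano on an aromatic carbon. In this assay, the expected step, a number no higher from compound 3 to compound 4 (the limit leaves the size open), is none beyond the scatter, and no direction can be expected with any confidence. This expectation leans on compound 1, which also carries an ester group and gives > 25000 nM, a limit and not a number. It is therefore likely that compound 4 will also be reported only as a limit. For compound 4 the estimated value is 25000 nM, with an expected range from 10000 nM to 50000 nM.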

Compound 4, half-maximal inhibitory concentration: 3000 nM
Estimate against measurement, compound 4: 8.3-fold (0.92 log units) above; the measured number lies below the stated range.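

In this assay, among these compounds, putting ethoxycarbonyl in place of cyano on an aromatic carbon, para to a large group, gives an at least 8.3-fold lower number from compound 3 to compound 4 (0.92 log units; beyond the scatter), a step beyond the scatter and the first readable change in this set. From the compounds shown here alone, compound 3 gives > 25000 nM, which is a limit and not a number, so the step has a lower bound and its full size stays open. The earlier compounds could not show that this position answers to the group it carries, or that a compound with the diethylamino side can reach a measurable value at all, and compound 4 is the only one shown to leave the limit: the limit of > 25000 nM in this assay, at which 3 of the 4 values shown sit.

The compounds shown do not tell whether the gain belongs to the carbonyl, to the ethyl chain or to the whole ethoxycarbonyl group, and a carboxylic acid, a primary amide, a methyl ester or an ester with a longer chain at the same place would be needed to separate these. They also leave open whether the diethylamino group itself is needed, for instance whether a pyrrolidine or a dimethylamino group on the other side of the core would hold the value of compound 4.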